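This account rests on a few compounds, and the source may have more. Where it says the series, first, only, none or still open, it means among the compounds named here.

Compound 1 `COc1cccc(Nc2ncc(C)c(Nc3nc4ccccc4s3)n2)c1` and compound 2 `Cc1cnc(Nc2ccc(N3CCCCC3)cc2)nc1Nc1nc2ccccc2s1` share a core and were tested in a functional assay on PC-3 cells (Homo sapiens) for antiproliferative activity, read by MTT assay, with a stated time of 48 h; a higher number here means a weaker inhibitor, a lower number a stronger inhibitor. Compound 1 gives > 50000 nM, which is a limit of the assay and not a number. Compound 2 likewise gives > 50000 nM, again a limit rather than a number. Compound 2 therefore stands at the limit of > 50000 nM in this assay, at which 2 of the 2 values shown sit, the edge of what this assay reports. Compound 3 `Cc1cnc(Nc2ccc(C(C)C)cc2)nc1Nc1nc2ccccc2s1` is to be measured in this assay and differs from compound 2 by isopropyl in place of piperidin-1-yl on an aromatic carbon. Among the compounds with values here, no measured step bounds this change, so no shift beyond the scatter is expected in this assay in either direction. For compound 3 the expected value is 50000 nM, within 20000 nM to 150000 nM. The estimated step of a number no higher from compound 2 to compound 3 (the limit leaves the size open) is thus close to none, with a limit the most likely outcome.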

Compound 3, half-maximal inhibitory concentration: > 50000 nM
Compound 3 was reported as a limit (the forecaster's own chance of this, stated with the estimate: 85%); the middle value sits exactly at the limit.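

Compound 1, compound 2 and compound 3 all stand at a limit in this assay, and the steps among them cannot be read. The compounds shown leave open which change on the shared core, if any, would give a measurable value in this assay.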